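Butyl in Place of 4-Ethoxyphenyl on the Amide Nitrogen

The source may report more compounds than this note shows. Statements on the series, on what has been measured and on what is new or still open speak of the compounds shown alone.

Compound 1, with the structure `CCOc1ccc(NC(=O)c2cccc(/C=C3\CC(=O)N(Cc4ccccc4)C3=O)c2)cc1`, was tested in an ADME assay on NCM460 cells (Homo sapiens) for cytotoxicity, read by MTT assay, with a stated time of 72 h; on this read-out higher numbers stand for weaker inhibition and lower numbers for stronger inhibition. In this assay compound 1 gives > 100000 nM, which is a limit of the assay rather than a measured number. Compound 2, `CCOc1ccc(NC(=O)c2cccc(/C=C3\CC(=O)N(c4ccccc4)C3=O)c2)cc1`, differs from it by phenyl in place of benzyl on an amide-type nitrogen in a ring. In this assay compound 2 also gives a limit, > 100000 nM. The step that the two limits leave unreadable from compound 1 to compound 2 therefore cannot be read. Compound 3, `CCCCCN1C(=O)C/C(=C\c2cccc(C(=O)Nc3cccc(F)c3)c2)C1=O`, likewise gives a limit in this assay, > 100000 nM. All three values rest at the limit of > 100000 nM in this assay, at which 3 of the 3 values shown sit.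

Compound 4, `CCCCNC(=O)c1cccc(/C=C2\CC(=O)N(Cc3ccccc3)C2=O)c1`, differs from compound 1 by butyl in place of 4-ethoxyphenyl on an amide-type nitrogen. Within the data shown here, none of the measured steps touches this part of the molecule, and the one measured step is unreadable, so no size or direction can be taken from the data. Given that compound 1 sits at a limit, compound 4 is expected to stay near that limit as well, with an estimated 150000 nM and a range from 50000 nM to 500000 nM. The expected step that the limit leaves unreadable from compound 1 to compound 4 is therefore no more than the usual scatter.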

Compound 4, half-maximal inhibitory concentration: > 100000 nM
Compound 4: no number, only a limit (the forecaster's own chance of this, stated with the estimate: 80%); the middle value lies beyond the limit too.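

In this assay compound 4 gives > 100000 nM, which is a limit and not a number. Compound 1 also sits at a limit, so the step between compound 1 and compound 4 cannot be read. The compounds shown leave open whether butyl in place of 4-ethoxyphenyl changes this read-out at all, because every value rests at the same point: the limit of > 100000 nM in this assay, at which 4 of the 4 values shown sit.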